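The source may hold more compounds than are shown below. What is called first, only, known or untested is meant among the compounds shown, and "the series" means these compounds.

Compounds measured in a functional assay on HepG2 cells (Homo sapiens) for inhibition, with a stated time of 72 h; a higher number here means a weaker inhibitor, a lower number a stronger inhibitor:

compound 1, `O=C(Nc1ccc(Cl)cc1)Nc1nc(Sc2c[nH]c3ccccc23)cc(N2CCCC2)n1`: 7870 nM
compound 2, `O=C(Nc1ccccc1)Nc1nc(Sc2c[nH]c3ccccc23)cc(N2CCCC2)n1`: 11400 nM
compound 3, `COc1ccc(NC(=O)Nc2nc(Sc3c[nH]c4ccccc34)cc(N3CCCC3)n2)cc1`: 20300 nM

Compound 2 stands second highest of the three numbers; its nearest neighbour is compound 1, with a 1.4-fold higher number from compound 1 to compound 2 (0.16 log units; within the scatter), and its furthest is compound 3, with a 1.8-fold higher number from compound 2 to compound 3 (0.25 log units; within the scatter), both within the scatter. For the measured compounds named here, the one step beyond the scatter is a 2.6-fold higher number from compound 1 to compound 3 (0.41 log units; beyond the scatter), a modest one.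

Compound 4, `O=C(Nc1ccccc1)Nc1nc(Sc2c[nH]c3ccccc23)cc(N2CCN(c3ccccn3)CC2)n1`, is not yet measured. It differs from compound 2 in 4-(pyridin-2-yl)piperazin-1-yl in place of pyrrolidin-1-yl on an aromatic carbon. All three measured steps change the substituent on the phenyl of the urea; none touches the pyrrolidin-1-yl or any group at its place. No measured step therefore bears on the change from compound 2 to compound 4, and the shown steps give no direction for it. With nothing to go on, no shift beyond the scatter is assumed in this assay, and the uncertainty is taken as wide.

For compound 4 the estimate is 10000 nM, with a range from 2000 nM to 50000 nM. This estimate corresponds to an expected step of a 1.1-fold lower number from compound 2 to compound 4 (0.06 log units; within the scatter).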

Compound 4, half-maximal inhibitory concentration: 8930 nM
Estimate against measurement, compound 4: 1.1-fold (0.05 log units) above; low and high end bracket the measured number.
By their numbers in this assay, from the lowest: compounds 1, 4, 2 and 3 (each within the scatter of the next, the first and the last beyond it).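

In this assay, for the compounds shown here, the position on the core next to the ring nitrogen, until now seen only with pyrrolidin-1-yl, also takes 4-(pyridin-2-yl)piperazin-1-yl, and the exchange gives a 1.3-fold lower number from compound 2 to compound 4 (0.11 log units; within the scatter). In this single pair, a group of 12 heavy atoms with two rings and 3 hydrogen-bond acceptors replaces one of 5 heavy atoms with one ring and 1 hydrogen-bond acceptor, without a shift beyond the scatter. Nothing at hand explains why the number holds across so large an exchange.

Still open, as far as these compounds go, is whether a morpholin-4-yl group, a dimethylamino group or a piperazine carrying a carboxylic acid at this position would also stay close to compound 2. Also open, from the compounds shown here alone, is whether the chloro and methoxy steps on the phenyl of the urea carry over to compounds bearing 4-(pyridin-2-yl)piperazin-1-yl.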